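Ethoxy to Methoxy: Cytotoxicity Expected to Stay Unchanged

The source may hold more compounds than are shown below. What is called first, only, known or untested is meant among the compounds shown, and "the series" means these compounds.

Compound 1 `CCOc1ccc2nc(Cl)c(/C=C3\SC(=S)NC3=O)cc2c1` was examined in a toxicity assay on THP-1 cells (Homo sapiens) for cytotoxicity, read by MTT assay, with a stated time of 48 h; a higher number here means a weaker inhibitor of growth, a lower number a stronger inhibitor of growth. In this assay compound 1 gives > 100 ug/mL, which is a limit of the assay rather than a measured number. Compound 2 `COc1ccc2cc(/C=C3\SC(=S)NC3=O)c(Cl)nc2c1` shares the same core, with its chloro and methoxy groups placed differently. In this assay compound 2 gives > 100 ug/mL, again a limit and not a number. Both values sit together at the limit of > 100 ug/mL in this assay, at which 2 of the 2 values shown sit, so neither compound showed measurable growth inhibition up to that point.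

Compound 3 `COc1ccc2nc(Cl)c(/C=C3\SC(=S)NC3=O)cc2c1` has not yet been tested. It differs from compound 1 in one place: hydrogen in place of methyl on a saturated chain carbon bound to an oxygen on an aromatic ring, or ethoxy to methoxy. Within the data shown here, no measured pair shows how this kind of change moves the read-out, so the size of the step is uncertain. The step that the limit leaves unreadable from compound 1 to compound 3 is expected to stay within the usual scatter, in no clear direction, because both measured compounds rest at the limit of > 100 ug/mL in this assay, at which 2 of the 2 values shown sit. Compound 3 is therefore expected to give about 150 ug/mL, within a range from 60 ug/mL to 400 ug/mL, most likely reported once more only as a limit.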

Compound 3, concentration for 50% growth inhibition: > 100 ug/mL
Compound 3 was reported as a limit; the forecaster's own chance of this, stated with the estimate: 85%; the middle value is on the limit's open side.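

Compound 1 and compound 3 both rest at a limit in this assay, so no step between them can be read: the limit of > 100 ug/mL in this assay, at which 3 of the 3 values shown sit.

The compounds shown leave open how far each one lies from that limit, and whether ethoxy and methoxy differ at all in their inhibition of growth of these cells.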